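The source may report more compounds than this note shows. Statements on the series, on what has been measured and on what is new or still open speak of the compounds shown alone.

Working notes on the series.

Compound 3 `COc1cc(Cl)cc(-c2nn(-c3cccc(NC(=O)Nc4ccc(Cl)c(Cl)c4)c3)cc2-c2ccncc2)c1` gives -70% in a functional assay on SK-MEL-2 cells (Homo sapiens) for inhibition, read by sulforhodamine B assay, with a stated time of 48 h, tested at 100 uM (a lower number here means a stronger effect, a higher number a weaker effect of the compound at the concentration tested), the second highest of three numbers. Its nearest neighbour is compound 2 `COc1cc(Cl)cc(-c2nn(-c3cccc(NC(=O)Nc4cc(C(F)(F)F)cc(C(F)(F)F)c4)c3)cc2-c2ccncc2)c1`, which in this assay gives -83%; its furthest is compound 1 `O=C(Nc1cccc(-n2cc(-c3ccncc3)c(-c3cc(O)cc(Cl)c3)n2)c1)Nc1ccc(Cl)c(Cl)c1`, which in this assay gives -52%. Within the data shown here, the only measured single-point step in the set is a number 18 percentage points lower from compound 1 to compound 3 (beyond the scatter), a change on the oxygen of the shared core that is not the kind of change made next.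

Compound 4 `COc1cc(Cl)cc(-c2nn(-c3cccc(NC(=O)c4cccc(C(F)(F)F)c4)c3)cc2-c2ccncc2)c1` differs from compound 3 in the urea part: 3-(trifluoromethyl)phenyl in place of (3,4-dichlorophenyl)amino on a carbonyl carbon. Among the measured compounds shown here, no measured step follows this change, so nothing in the set speaks to it directly; compound 2 and compound 3 show only that two different substituted phenyl groups on the urea give numbers beyond the scatter apart. Given that the change removes the hydrogen-bond donor counted in the leaving group and that no measured step supports a stronger effect, a weaker effect is expected for compound 4, and the step of a number 20 percentage points higher from compound 3 to compound 4 (beyond the scatter) is estimated accordingly. Compound 4 is expected to give -50% in this assay, within the range -85% to -15%.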

Compound 4, a percentage reported as activity, at one concentration (the size of the read-out at that concentration, not a potency): 47%
Beside the measured number, compound 4's estimate is 97 percentage points below it; measured number outside the range, above it.
By their numbers in this assay, from the lowest: compound 2; then compound 3; then compound 1; then compound 4.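

In this assay the exchange on the carbonyl carbon, 3-(trifluoromethyl)phenyl in place of (3,4-dichlorophenyl)amino, gives a number 117 percentage points higher from compound 3 to compound 4 (beyond the scatter) and so turns a negative read-out into a positive one. Among these compounds, the earlier compounds all keep the (substituted phenyl)amino arrangement on this carbonyl carbon and all read negative, so this is the first sign that the series' read-out depends heavily on what sits at this position. Nothing shown accounts for the size of this step.

The step removes the amino nitrogen and changes the ring substituents at once, so the two contributions cannot be separated. As far as these compounds go, whether the nitrogen or the substituents carry the effect remains open, and (3-(trifluoromethyl)phenyl)amino or 3,4-dichlorophenyl on the same carbonyl carbon would bear directly on that question.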